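Shortening a chain on a low-toxicity sultone series

The compounds below may be only part of what the source reports. "The series", "measured", "known", "first", "only" and "open" are said of these compounds alone.

Among the compounds with values here, compound 1 `CCC1(Cc2ccccc2)OS(=O)(=O)C=C1OCCCCc1ccccc1` is the only member of this set with a proper number in an ADME assay on HEL cells (Homo sapiens) for cytotoxicity, with a stated time of 3 days; on this read-out lower numbers stand for higher toxicity in this test and higher numbers for lower toxicity in this test: compound 1 gives 99000 nM, the sole value here that is not a limit. Compound 2 `CCC1(Cc2ccccc2)OS(=O)(=O)C=C1OCC#N` carries a cyano in place of the 3-phenylpropyl. For compound 2 this assay reports only a limit, > 200000 nM. Compound 3 `CCC1(Cc2ccccc2)OS(=O)(=O)C=C1OCc1ccc(F)cc1` carries a 4-fluorophenyl at the same place. For compound 3 this assay again reports only a limit, > 50000 nM. The measured steps are therefore thin: an at least 2.0-fold higher number from compound 1 to compound 2 (0.30 log units; that floor lies within the scatter), and a step that the limit leaves unreadable from compound 1 to compound 3, while a step that the two limits leave unreadable from compound 2 to compound 3. Compound 4 `CCC1(Cc2ccccc2)OS(=O)(=O)C=C1OCCCc1ccccc1` differs from compound 1 in one place, (phenyl in place of benzyl on a saturated chain carbon, three bonds along the chain from an oxygen on an unsaturated carbon). Within the data shown here, none of the measured steps removes a single chain carbon while keeping the phenyl, so no step bears directly on this change; what the set does show is that every replacement at this position has kept toxicity low, with compound 1 at 99000 nM as the reference point. The expected step is therefore small: a 1.0-fold higher number from compound 1 to compound 4 (0.00 log units; within the scatter), meaning compound 4 is estimated at 100000 nM, within a range from 40000 nM to 250000 nM.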

Compound 4, half-maximal cytotoxic concentration: 133000 nM
Compound 4: middle estimate off by 1.3-fold (0.12 log units), on the low side, within the range that was stated.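

In this assay, phenyl in place of benzyl gives a 1.3-fold higher number from compound 1 to compound 4 (0.13 log units; within the scatter), so this change in the chain leaves the read-out unmoved beyond ordinary repeat variation. Compound 4 also gives this position a second proper number, which shows that the low toxicity of compound 1 is not confined to the 3-phenylpropyl chain. Set against the cyano group, phenethyl gives an at least 1.5-fold lower number from compound 2 to compound 4 (0.17 log units; that floor lies within the scatter), so no real separation between these two groups can be claimed. The step involving compound 3 cannot be read, because compound 3 is reported only as a limit: the limit of > 50000 nM in this assay, at which 1 of the 4 values shown sits.

The compounds shown leave open whether a much longer chain, or an amine or a carboxylic acid at the end of the chain, would keep the number this high. They also leave open whether any group at this position can bring the number down by more than the scatter, since the steps that can be read here do not get beyond it.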